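This account rests on a few compounds, and the source may have more. Where it says the series, first, only, none or still open, it means among the compounds named here.

Going by the values given here, compound 1, with the structure `Cc1cc(C)c(CN2CCc3c(Cl)cc([C@H](CO)[C@H]4CCOC4)c(Cl)c3C2=O)c(=O)[nH]1`, is the only compound of the pair with a numerical result: in an assay on cells for inhibition of histone-lysine N-methyltransferase EZH2 (Homo sapiens), read by ELISA, with a stated time of 72 h (a higher number here means a weaker inhibitor, a lower number a stronger inhibitor), compound 1 gives 10 nM. Compound 2, with the structure `COc1cc(C)[nH]c(=O)c1CN1CCc2c(Cl)cc([C@@H](O)C3COC3)c(Cl)c2C1=O`, reaches only a limit in this assay, where compound 2 gives > 32000 nM, which is the limit of the assay and not a measured number (the limit of > 32000 nM in this assay, at which 1 of the 2 values shown sits). Compound 2 differs from compound 1 in several places at once, so the two values say nothing about any single change.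

Compound 3, with the structure `Cc1cc(C)c(CN2CCc3c(Cl)cc([C@@H](CO)[C@H]4CCCO4)c(Cl)c3C2=O)c(=O)[nH]1`, has the same atoms as compound 1 joined differently: a group of 8 heavy atoms (6 carbon, 2 oxygen; one five-membered non-aromatic ring with 1 hetero atom) in place of a group of 8 heavy atoms (6 carbon, 2 oxygen; one five-membered non-aromatic ring with 1 hetero atom), on an aromatic carbon. No measured step of this kind is available among these compounds. With the same atoms and the same counts of donors and acceptors kept, a modest loss in this assay is expected, so the step from compound 1 to compound 3 is estimated at a 3.0-fold higher number from compound 1 to compound 3 (0.48 log units; beyond the scatter). Compound 3 is therefore expected to give about 30 nM, with a range from 8 nM to 150 nM.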

Compound 3, half-maximal inhibitory concentration: 1020 nM
Estimate against measurement, compound 3: 34-fold (1.53 log units) below; measured number above the stated range.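

Going by these compounds alone, compounds 1 and 3 give the first comparison that differs in one place, and in this assay it shows a 100-fold higher number from compound 1 to compound 3 (2.01 log units; beyond the scatter). At this aromatic carbon, ortho to a chloro group, the result therefore depends on how the group is joined and not only on its composition, since both groups have the same atoms, the same hydrogen-bond donor and acceptor counts, one five-membered non-aromatic ring with 1 hetero atom and 2 defined stereocentres. Nothing measured here accounts for the size of this step.

From the compounds shown here alone, the pair cannot separate the way the ring is attached from the arrangement at the stereocentres, so it remains open which of these carries the step. Going by these compounds, it also remains open how this position would respond to a group carrying an amine or a carboxylic acid.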